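A few compounds are considered here, and "the series" means these few. Any claim that something is new, unique, unknown or untested is made for them only; others in the source may bear on it.

Among the measured compounds shown here, in a functional assay on PC-3 cells (Homo sapiens) for antiproliferative activity, read by WST assay, with a stated time of 72 h (on this read-out higher numbers stand for an effect only at larger amounts of compound and lower numbers for an effect already at smaller amounts), compound 2 (`CCCCCCCCCCc1c(C)c(CCCCCCCCCC)c2[n+](c1C)CCC2`) gives 0.6 uM, the only actual number so far. Compound 1 (`CCCCCCCC/C=C\c1c(C)cc(C)nc1CCCOC`) reads > 30 uM in this assay, and this is a limit of the assay, not a number. Compound 3 (`CCCCCCCCCCc1c(C)cc2[n+](c1C)CCC2`) is still unmeasured. It differs from compound 2 in one place: hydrogen in place of decyl on an aromatic carbon, two atoms from the ring nitrogen. Compound 3 keeps a decyl group. For the measured compounds named here, no measured pair isolates this change, so the size of the step is a judgement. Starting from compound 2 at 0.6 uM, a moderate loss of potency in this assay, beyond the usual scatter, is expected. The expected change is a 6.7-fold higher number from compound 2 to compound 3 (0.82 log units; beyond the scatter). For compound 3 the estimated value is 4 uM, with an expected range of 1 uM to 20 uM.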

Compound 3, concentration for half-maximal effect: 1.5 uM
Compound 3: the middle estimate sits 2.7-fold (0.43 log units) above what was measured; the range from low to high includes it.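

Among the compounds shown here, replacing decyl with hydrogen on the aromatic carbon two atoms from the ring nitrogen gives, in this assay, a 2.5-fold higher number from compound 2 to compound 3 (0.40 log units; beyond the scatter), the first step that can be read. The second decyl group is therefore not required for activity in the low micromolar range: compound 3, which keeps one decyl group, still gives 1.5 uM. Compound 1 stands in no step with the other two, and its reading is a limit, not a number: the limit of > 30 uM in this assay, at which 1 of the 3 values shown sits.

Open, as far as these compounds go, is whether this position tolerates anything between hydrogen and decyl, such as a butyl chain, or something longer or different, such as a dodecyl chain, an amine or a carboxylic acid. Also open, from the compounds shown here alone, is what the decyl group kept in compound 3 contributes, with hydrogen or a butyl chain in its place.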